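The compounds below may be only part of what the source reports. "The series", "measured", "known", "first", "only" and "open" are said of these compounds alone.

Measured so far in an in vitro ADME assay on microsomes (Rattus norvegicus) for metabolic stability; on this read-out lower numbers stand for a shorter-lived compound and higher numbers for a longer-lived compound:
- compound 1 `Cc1c2c(n3c1CCN(C(=O)CN)C[C@@H](C)[C@H](C)Nc1cc-3ccc1C(N)=O)CC(C)(C)CC2=O`: > 0.5 h
- compound 2 `Cc1c2c(n3c1CCN(C(=O)C(C)(C)N)C[C@@H](C)[C@H](C)Nc1cc-3ccc1C(N)=O)CC(C)(C)CC2=O`: > 0.5 h
- compound 3 `Cc1c2c(n3c1CCN(C(=O)C1(N)CC1)C[C@@H](C)[C@H](C)Nc1cc-3ccc1C(N)=O)CC(C)(C)CC2=O`: > 0.5 h

Compound 3 stands at > 0.5 h, which is a limit and not a number. Among the measured compounds shown here, the series so far offers only (the limit of > 0.5 h in this assay, at which 3 of the 3 values shown sit).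

Compound 4 `Cc1c2c(n3c1CCN(C(=O)[C@@H](O)C(C)C)C[C@@H](C)[C@H](C)Nc1cc-3ccc1C(N)=O)CC(C)(C)CC2=O` carries 1-hydroxy-2-methylpropyl in place of 1-aminocyclopropyl on a carbonyl carbon.

The measured changes at this place are a step that the two limits leave unreadable from compound 1 to compound 2, a step that the two limits leave unreadable from compound 1 to compound 3 and a step that the two limits leave unreadable from compound 2 to compound 3. None gives a readable size, so no step beyond the scatter is expected in either direction.

The expected change is a step that the limit leaves unreadable from compound 3 to compound 4.

For compound 4 the estimated half-life is 0.8 h, with an expected range from 0.3 h to 2 h.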

Compound 4, half-life: 0.317 h
Compound 4: the middle estimate sits 2.5-fold (0.40 log units) above what was measured; the range from low to high includes it.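

In this assay, among the compounds shown here, compound 4 is the first group on this carbonyl carbon to give a number and not a limit, so the change from an amine-bearing group to 1-hydroxy-2-methylpropyl can be read for the first time: an at least 1.5-fold lower number from compound 3 to compound 4 (0.19 log units; that floor lies within the scatter), an at least 1.5-fold lower number from compound 2 to compound 4 (0.19 log units; that floor lies within the scatter) and an at least 1.5-fold lower number from compound 1 to compound 4 (0.19 log units; that floor lies within the scatter). Each of these steps is only a floor, and the steps among compound 1, compound 2 and compound 3 cannot be read: the limit of > 0.5 h in this assay, at which 3 of the 4 values shown sit.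

From the compounds shown here alone, how far compound 4 truly lies from the others stays open. So does whether the hydroxyl or the open chain goes with the step, which a 1-amino-2-methylpropyl or 1-hydroxycyclopropyl group would separate.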